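From dipropylamino to anilino on the shared core

The compounds below may be only part of what the source reports. "The series", "measured", "known", "first", "only" and "open" are said of these compounds alone.

Compound 1 (`O=C1C=C(NC2CCCC2)C(=O)c2c1nc1n2[C@H]2OC[C@@H](O)[C@H]2OC1`), compound 2 (`O=C1C=C(Nc2ccc(C(F)(F)F)cc2)C(=O)c2c1nc1n2[C@H]2OC[C@@H](O)[C@H]2OC1`) and compound 3 (`CCCN(CCC)C1=CC(=O)c2nc3n(c2C1=O)[C@H]1OC[C@@H](O)[C@H]1OC3`) share one core and differ in the amine group attached to it. In a functional assay on MCF7 cells (Homo sapiens) for inhibition, read by sulforhodamine B assay (a higher number here means a weaker inhibitor, a lower number a stronger inhibitor), compound 3 gives > 16000 nM, which is a limit and not a number. Compound 1 gives > 16000 nM, also a limit. Compound 2 gives > 4000 nM, again a limit. The series therefore stands only at the limit of > 16000 nM in this assay, at which 2 of the 3 values shown sit, and at the limit of > 4000 nM in this assay, at which 1 of the 3 values shown sits, with no numerical reading yet.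

Compound 4 (`O=C1C=C(Nc2ccccc2)C(=O)c2c1nc1n2[C@H]2OC[C@@H](O)[C@H]2OC1`) is not yet measured. It carries anilino in place of dipropylamino on a double-bonded ring carbon.

Going by the values given here, two measured steps bear on this change: a step that the two limits leave unreadable from compound 1 to compound 2, with 4-(trifluoromethyl)phenyl in place of cyclopentyl on an amine nitrogen, and a step that the two limits leave unreadable from compound 1 to compound 3, with dipropylamino in place of cyclopentylamino. Neither has a readable size, and neither shows a direction. Among the compounds with values here, the nearest guide is compound 2 at > 4000 nM, a limit, as the only measured compound with an aromatic ring on its amine nitrogen. Weak inhibition is expected to persist, and a limit rather than a number is a likely outcome. The expected step is an at least 2.0-fold lower number from compound 3 to compound 4 (0.30 log units; that floor lies within the scatter), modest and toward a stronger inhibitor in this assay. Compound 4 is estimated at 8000 nM, with an expected range from 2500 nM to 25000 nM.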

Compound 4, half-maximal inhibitory concentration: > 4000 nM
Compound 4 ended at the assay's limit; the forecaster's own chance of this, stated with the estimate: 60%; the middle value does not contradict the limit.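

In this assay compound 4 gives > 4000 nM, a limit and not a number. Its steps to compound 1, compound 2 and compound 3 cannot be read, in size or in direction. The compounds shown leave open whether any amine group on the shared core gives a numerical reading in this assay, and how these four compounds rank.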